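Swapping Methoxy for Iodo on a Weak Duckweed Inhibitor

The compounds below may be only part of what the source reports. "The series", "measured", "known", "first", "only" and "open" are said of these compounds alone.

Three thiosemicarbazones built on one shared core have been tested. Compound 1 `Cc1cccc(NC(=S)N/N=C2\C(=O)Nc3ccc([N+](=O)[O-])cc32)c1` gives 20% in a functional assay on the whole organism for inhibition, with Lemna aequinoctialis as the target, tested at 100 ug/mL; on this read-out higher numbers stand for more inhibition of growth at the one concentration tested and lower numbers for less inhibition of growth. Compound 2 `COc1ccc(NC(=S)N/N=C2\C(=O)Nc3ccc([N+](=O)[O-])cc32)cc1` gives 15%, and compound 3 `O=C1Nc2ccc([N+](=O)[O-])cc2/C1=N/NC(=S)Nc1ccccc1C(F)(F)F` gives 15%. Compound 2 thus sits level with compound 3 at the low end of these numbers, and the gap a number 5 percentage points lower from compound 1 to compound 2 (within the scatter) lies within the scatter. Compound 4 `O=C1Nc2ccc([N+](=O)[O-])cc2/C1=N/NC(=S)Nc1ccc(I)cc1` differs from compound 2 by iodo in place of methoxy on an aromatic carbon. For the measured compounds named here, only the step from compound 1 to compound 2 bears on this, and it was small, so no movement beyond the scatter is expected: compound 4 is estimated at 17%, between 5% and 30%, a shift of a number 2 percentage points higher from compound 2 to compound 4 (within the scatter).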

Compound 4, percent growth inhibition at one concentration: 10%
Estimate against measurement, compound 4: 7 percentage points above, within the range that was stated.
By their numbers in this assay, from the lowest: compounds 4, 2, 3 and 1 (each within the scatter of the next).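

Iodo in place of methoxy gives a number 5 percentage points lower from compound 2 to compound 4 (within the scatter) in this assay, so removing the hydrogen-bond acceptor of methoxy from this aromatic carbon leaves no change that can be told from the scatter. Even the wider comparison, with 4-iodophenyl in place of 3-methylphenyl, gives a number 10 percentage points lower from compound 1 to compound 4 (within the scatter) and stays inside that scatter. Nothing available explains these small steps.

Still open, on these data alone, is whether an amine or a carboxylic acid on this aromatic carbon would move the read-out beyond the scatter. Whether any group here can lift growth inhibition well above these low values also remains unanswered.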